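Cytotoxicity notes: phenoxy to acetamido on the pendant ring

A few compounds are considered here, and "the series" means these few. Any claim that something is new, unique, unknown or untested is made for them only; others in the source may bear on it.

Compound 1 `CCOC(=O)c1c(-c2cc(F)cc(OC)c2)[nH]c2cc(OC)ccc2c1=O` and compound 2 `CCOC(=O)c1c(-c2cccc(Oc3ccccc3)c2)[nH]c2cc(OC)ccc2c1=O` share one core and differ only in the group carried on the pendant aromatic ring. In an ADME assay on HepG2 cells (Homo sapiens) for cytotoxicity, read by luminescence, with a stated time of 72 h (a lower number here means that less compound is needed, a higher number that more compound is needed for the effect), compound 1 reports > 21500 nM, which is a limit of the assay and not a number. In this assay compound 2 reports > 21500 nM, again a limit rather than a number. Compound 2 therefore stands where every shown value stands: the limit of > 21500 nM in this assay, at which 2 of the 2 values shown sit. Within the data shown here, no step between measured compounds is available, so nothing here shows how a change on that ring moves the read-out.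

Compound 3 `CCOC(=O)c1c(-c2cccc(NC(C)=O)c2)[nH]c2cc(OC)ccc2c1=O` carries acetamido in place of phenoxy on an aromatic carbon. With both measured values sitting at the same limit, the expected step that the limit leaves unreadable from compound 2 to compound 3 is none beyond the scatter. Compound 3 is expected to give 30000 nM, within 12000 nM to 80000 nM, most probably reported once more as a limit.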

Compound 3, half-maximal effective concentration: > 21500 nM
Compound 3 gave a limit, no number (the forecaster's own chance of this, stated with the estimate: 80%); the middle value is on the limit's open side.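

In this assay, among these compounds, compound 2 and compound 3 both end at a limit and not at a number, and no step between them can be read: the limit of > 21500 nM in this assay, at which 3 of the 3 values shown sit. The compounds shown leave open whether any change on the pendant ring moves the read-out at all.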